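Trifluoromethyl Replaces Methoxy on the Pendant Phenyl

The source may report more compounds than this note shows. Statements on the series, on what has been measured and on what is new or still open speak of the compounds shown alone.

Compound 1, `CNC(=O)c1cc(Oc2ccc(NC(=O)c3cc(-c4ccc(F)cc4)ncn3)cc2F)ccn1`: > 100000 nM
Compound 2, `CNC(=O)c1cc(Oc2ccc(NC(=O)c3cc(-c4ccc(OC)cc4)ncn3)cc2F)ccn1`: 34500 nM

In a functional assay on A549 cells (Homo sapiens) for cytotoxicity, read by MTT assay, with a stated time of 72 h (a lower number here means a stronger inhibitor, a higher number a weaker inhibitor), compound 1 reaches only a limit, > 100000 nM. Compound 2 gives 34500 nM, the only number shown. Compound 1 sits at a limit of the assay (the limit of > 100000 nM in this assay, at which 1 of the 2 values shown sits). For the measured compounds named here, the single measured step is an at least 2.8-fold lower number from compound 1 to compound 2 (0.46 log units; beyond the scatter). Compound 3, `CNC(=O)c1cc(Oc2ccc(NC(=O)c3cc(-c4ccc(C(F)(F)F)cc4)ncn3)cc2F)ccn1`, differs from compound 2 by trifluoromethyl in place of methoxy on an aromatic carbon. Going by the values given here, no measured step compares these two groups directly; only the step from compound 1 to compound 2 concerns the same position. The expected step is a 1.7-fold higher number from compound 2 to compound 3 (0.24 log units; within the scatter), a weaker number, with wide uncertainty. Compound 3 is estimated at 60000 nM, between 15000 nM and 250000 nM.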

Compound 3, half-maximal inhibitory concentration: > 100000 nM
Compound 3 gave a limit, no number (the forecaster's own chance of this, stated with the estimate: 40%); middle value at least 1.6-fold (0.22 log units) from the limit.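

In this assay, for the compounds shown here, the exchange of methoxy for trifluoromethyl on this aromatic carbon brings an at least 2.8-fold higher number from compound 2 to compound 3 (0.46 log units; beyond the scatter) and loses the only measurable number in the set. Of the three groups shown here, only methoxy gives a number, while compound 1 and compound 3 both end at a limit, not a number: the limit of > 100000 nM in this assay, at which 2 of the 3 values shown sit. The step from compound 1 to compound 3 therefore cannot be read. The compounds shown leave open whether an ethoxy or a dimethylamino group at this place would give a number, and how far any such number would lie from that of compound 2.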